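A few compounds are considered here, and "the series" means these few. Any claim that something is new, unique, unknown or untested is made for them only; others in the source may bear on it.

Compound 1 `O=C(Nc1ccc(F)c(-c2nc3ncc(-c4ccccc4F)cc3[nH]2)c1)N1CCCC1`: 2230 nM
Compound 2 `O=C(Nc1ccc(F)c(-c2nc3ncc(-c4cc(F)cc(F)c4)cc3[nH]2)c1)N1CCCC1`: 4800 nM
Compound 3 `Cc1nc(C)c(C(=O)Nc2ccc(F)c(-c3nc4ncc(-c5ccccc5Cl)cn4n3)c2)o1`: 39300 nM

All three were measured in an ADME assay on the whole organism (Mus musculus, strain Swiss Webster) for pharmacokinetics, read by LC-MS, at a dose of 50 mg/kg by the oral route; a lower number here means less compound in the circulation, a higher number more compound in the circulation at the dose given. Compound 2 stands second highest of the three numbers. Its nearest neighbour is compound 1, separated from it by a 2.2-fold higher number from compound 1 to compound 2 (0.33 log units; beyond the scatter); its furthest is compound 3, which gives 39300 nM.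

Compound 4 `O=C(Nc1ccc(F)c(-c2nc3ncc(-c4cccnc4F)cc3[nH]2)c1)N1CCCC1` has not yet been measured. It differs from compound 2 in one place: 2-fluoropyridin-3-yl in place of 3,5-difluorophenyl on an aromatic carbon. Among the measured compounds shown here, only one measured step touches this part of the molecule, namely a 2.2-fold higher number from compound 1 to compound 2 (0.33 log units; beyond the scatter), a modest rise on going from one fluorine on the ring to two. For the measured compounds named here, the incoming 2-fluoropyridin-3-yl carries a single fluorine, as the 2-fluorophenyl of compound 1 does, but it also brings a ring nitrogen, and no measured pair shows what such a nitrogen does in this assay. The expectation for compound 4 is therefore a number somewhat lower than that of compound 2, drifting back toward compound 1, and the step of a 1.7-fold lower number from compound 2 to compound 4 (0.23 log units; within the scatter) is estimated to be small, possibly within the scatter. On that basis compound 4 is expected to give 2800 nM, with a range from 1100 nM to 7500 nM.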

Compound 4, maximal plasma concentration: 25600 nM
The estimate for compound 4 lay 9.1-fold (0.96 log units) below the measured number; the measured number lies above the stated range.
By their numbers in this assay, from the lowest: compound 1; then compound 2; then compounds 4 and 3 (each within the scatter of the next).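

In this assay, among the compounds shown here, this position on the shared core proves far more sensitive than the one earlier step suggested: the change from 2-fluorophenyl to 3,5-difluorophenyl gave only a 2.2-fold higher number from compound 1 to compound 2 (0.33 log units; beyond the scatter), whereas 2-fluoropyridin-3-yl in place of 3,5-difluorophenyl gives a 5.3-fold higher number from compound 2 to compound 4 (0.73 log units; beyond the scatter), even though the incoming ring carries fewer fluorines. The closest comparison is with 2-fluorophenyl, since both rings carry one fluorine and the incoming ring also holds a nitrogen: this step gives an 11-fold higher number from compound 1 to compound 4 (1.06 log units; beyond the scatter), so among these three compounds the ring nitrogen, rather than the count of fluorines, goes with the largest rise. Nothing in the data shown explains why a ring nitrogen at this position goes with more compound in the circulation.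

The compounds shown leave open whether the fluorine on the new ring contributes at all, which a plain pyridin-3-yl would help to settle. They also leave open whether the rise depends on where the nitrogen sits or how many there are, which a pyridin-4-yl or a pyrimidinyl ring would test.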